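This account rests on a few compounds, and the source may have more. Where it says the series, first, only, none or still open, it means among the compounds named here.

Measured so far:
- compound 1 `O=C(CCCCCCCCn1cc(-c2cccnc2)nn1)Nc1ccccc1Cc1ccccc1`: 74.7%
- compound 2 `O=C(CCCCCCn1cc(-c2cccnc2)nn1)Nc1ccccc1Oc1ccccc1`: 81.3%

Both were tested in a functional assay on SH-SY5Y cells (Homo sapiens) for cytotoxicity, tested at 300 nM; on this read-out lower numbers stand for a stronger effect and higher numbers for a weaker effect at the one concentration tested. Compound 2 stands within the scatter of compound 1, so the two numbers cannot be told apart. Compound 3 `O=C(CCCCCCn1cc(-c2cccnc2)nn1)Nc1ccccc1Cl` has not been measured yet. It differs from compound 2 by chloro in place of phenoxy on an aromatic carbon. Among the measured compounds shown here, no pair of measured compounds shows what such a change does, so the step from compound 2 to compound 3 is expected to stay within the scatter, with no clear direction, which means a number 1.3 percentage points lower from compound 2 to compound 3 (within the scatter). Compound 3 is therefore estimated to give 80%, most likely between 62% and 96%.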

Compound 3, a percentage reported as activity, at one concentration (the size of the read-out at that concentration, not a potency): 79.5%
Beside the measured number, compound 3's estimate is 0.5 percentage points above it; the measured number falls inside the stated range.
By their numbers in this assay, from the lowest: compounds 1, 3 and 2 (each within the scatter of the next).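

In this assay, replacing the whole phenoxy group, aromatic ring included, with a single chloro atom on this aromatic carbon gives a number 1.8 percentage points lower from compound 2 to compound 3 (within the scatter) and so leaves the read-out indistinguishable. At this one concentration, this position therefore tolerates a large loss of size without a clear shift, at least for this pair. Nothing measured here explains this result. As far as these compounds go, what a methoxy group, an amine or a carboxylic acid would do on the same carbon remains open. So does whether a chloro group would behave alike on a longer chain.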